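From 1,3-Benzoxazol-2-yl to 1,3-Benzothiazol-2-yl at the Limit

This account rests on a few compounds, and the source may have more. Where it says the series, first, only, none or still open, it means among the compounds named here.

In an ADME assay on BJ cells (Homo sapiens) for cytotoxicity, with a stated time of 72 h (a lower number here means that less compound is needed, a higher number that more compound is needed for the effect), compound 1 `COc1ccc(-c2nc3ccccc3o2)cc1NC(=O)c1cc([N+](=O)[O-])ccc1Cl` returns no number, only a limit of > 25000 nM. Compound 2 `O=C(Nc1nc2c(Cl)cccc2s1)c1cc([N+](=O)[O-])ccc1Cl` also gives only a limit, > 27000 nM. Compound 3 `O=C(Nc1ccc(Cl)c(-c2nc3ccccc3s2)c1)c1cc([N+](=O)[O-])ccc1Cl` gives a limit too, > 25000 nM. Compound 1 sits at the limit of > 25000 nM in this assay, at which 2 of the 3 values shown sit, so no measured number places it against the other two.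

Compound 4 `COc1ccc(-c2nc3ccccc3s2)cc1NC(=O)c1cc([N+](=O)[O-])ccc1Cl` differs from compound 1 in one place: 1,3-benzothiazol-2-yl in place of 1,3-benzoxazol-2-yl on an aromatic carbon. In words, 1,3-benzothiazol-2-yl takes the place of 1,3-benzoxazol-2-yl on an aromatic carbon, para to a methoxy group, while the rest of the molecule stays the same. Going by the values given here, no measured pair shows directly what this exchange does in this assay.

The nearest guide is compound 3, which carries the same 1,3-benzothiazol-2-yl group and stays at a limit of > 25000 nM, so a similar result is expected for compound 4. No change beyond the usual scatter is expected in either direction, and the estimated step is a step that the limit leaves unreadable from compound 1 to compound 4. Compound 4 is estimated at 27000 nM, with an expected range of 13000 nM to 55000 nM, and the assay will most likely report only a limit again.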

Compound 4, half-maximal effective concentration: > 25000 nM
Compound 4 gave a limit, no number; the forecaster's own chance of this, stated with the estimate: 85%; the middle value does not contradict the limit.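

In this assay compound 1 and compound 4 both give only a limit, not a number, and no step between these two compounds can be read: the limit of > 25000 nM in this assay, at which 3 of the 4 values shown sit.

The compounds shown leave open whether 1,3-benzothiazol-2-yl in place of 1,3-benzoxazol-2-yl changes the concentration needed in this assay at all, and none of the four compounds gives a measured number there.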